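The source may hold more compounds than are shown below. What is called first, only, known or untested is meant among the compounds shown, and "the series" means these compounds.

Of the compounds shown here, two have been measured in a functional assay on SMMC-7721 cells (Homo sapiens) for inhibition, read by MTT assay, with a stated time of 72 h, tested at 10 uM; a lower number here means a weaker effect, a higher number a stronger effect of the compound at the concentration tested. Compound 1, with the structure `Fc1ccccc1COc1ccccc1/C=C/C(/C=C/c1ccccn1)=N/Oc1ncnc2cc(Cl)ccc12`, gives 94.8% in this assay. Compound 2, with the structure `Cc1cccc2ncnc(O/N=C(\C=C\c3ccccn3)/C=C/c3ccccc3OCc3ccc(Cl)cc3)c12`, gives 94.5% in this assay. These two values lie within the usual scatter of repeated measurements of each other, so neither compound can be set apart from the other on this evidence; both show strong inhibition at the concentration tested.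

Compound 3, with the structure `Clc1ccc(COc2ccccc2/C=C/C(/C=C/c2ccccn2)=N/Oc2ncnc3cc(Cl)ccc23)cc1`, has not yet been measured. It differs from compound 2 in one place: 7-chloroquinazolin-4-yl in place of 5-methylquinazolin-4-yl on an oxygen. Compound 1 already carries the 7-chloroquinazolin-4-yl group on the oxygen and reaches a value that sits alongside that of compound 2, so the swap of this group has not been seen to move the number outside the scatter here.

The step from compound 2 to compound 3 is therefore expected to be small, a number 1.5 percentage points lower from compound 2 to compound 3 (within the scatter), with no direction beyond the scatter. Compound 3 is estimated to give 93% in this assay, with a range from 82% to 98%.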

Compound 3, a percentage reported as inhibition, at one concentration (the size of the read-out at that concentration, not a potency): 94.8%
The estimate for compound 3 lay 1.8 percentage points below the measured number, within the range that was stated.
By their numbers in this assay, from the lowest: compounds 2, 1 and 3 (each within the scatter of the next).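

The two new pairs each isolate a single change, which compounds 1 and 2 could not do because they differ in more than one place. In this assay, 7-chloroquinazolin-4-yl in place of 5-methylquinazolin-4-yl on the oxygen gives a number 0.3 percentage points higher from compound 2 to compound 3 (within the scatter), and 4-chlorophenyl in place of 2-fluorophenyl on the saturated chain carbon gives no change at the digits printed from compound 1 to compound 3 (within the scatter), so neither swap has been seen to move the number beyond the scatter at the one concentration tested. Nothing measured here explains why both swaps leave the read-out where it stands.

On these data alone, all three compounds give a high reading at a single concentration, so whether any of them has a stronger or weaker effect at other concentrations remains unknown, since a lower concentration or a full dose-response series might separate compounds that look alike here. As far as these compounds go, it also remains open whether this tolerance extends beyond chlorine, methyl and fluorine to quite different groups, such as a carboxylic acid or an amine on either aromatic end, or a longer chain in place of the single saturated carbon bound to the oxygen.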